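The compounds below may be only part of what the source reports. "The series", "measured", "known", "first", "only" and "open" are said of these compounds alone.

Three sulfonamides built on the shared core have been tested for inhibition of growth in a breast-derived cell line. In a functional assay on MCF7 cells (Homo sapiens) for inhibition, read by MTT assay, with a stated time of 72 h (on this read-out higher numbers stand for weaker inhibition of growth and lower numbers for stronger inhibition of growth), compound 1 `O=S(=O)(NCCNCc1cccc2ccccc12)c1cc(C(F)(F)F)cc(C(F)(F)F)c1` gives 18000 nM. Compound 2 `COc1ccc(CNCCCNS(=O)(=O)c2cc(C(F)(F)F)cc(C(F)(F)F)c2)cc1OC` gives 1900 nM in this assay, and compound 3 `O=S(=O)(NCCCNCc1ccc(-c2ccccc2)cc1)c1cc(C(F)(F)F)cc(C(F)(F)F)c1` gives 1700 nM. Compound 2 thus stands second highest of the three numbers; its value and that of compound 3 lie within the scatter of each other, whereas compound 1 sits well above it, beyond the scatter.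

Compound 4 `COc1cccc(CNCCCNS(=O)(=O)c2cc(C(F)(F)F)cc(C(F)(F)F)c2)c1` has not yet been measured in this assay. It differs from compound 2 in one place: hydrogen in place of methoxy on an aromatic carbon. Among the compounds with values here, no pair of measured compounds differs in a single place, so the size of this step has no direct precedent among the three. Within the data shown here, compounds 2 and 3, which carry quite different aromatic groups at the benzyl end, nonetheless give numbers within the scatter of each other, and nothing among the measured compounds points to a large effect of one methoxy group. Therefore a step of a 1.3-fold higher number from compound 2 to compound 4 (0.12 log units; within the scatter) is expected, not beyond the scatter in either direction. Compound 4 is estimated to give 2500 nM in this assay, within a range from 1000 nM to 6000 nM.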

Compound 4, concentration for 50% growth inhibition: 2400 nM
Compound 4: the middle estimate sits 1.0-fold (0.02 log units) above what was measured; the measured number falls inside the stated range.
By their numbers in this assay, from the lowest: compounds 3, 2 and 4 (each within the scatter of the next); then compound 1.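

In this assay the change from 3,4-dimethoxybenzyl to 3-methoxybenzyl is a 1.3-fold higher number from compound 2 to compound 4 (0.10 log units; within the scatter) and gives the first measured size for a change in one place among these compounds. On this aromatic carbon, ortho to a methoxy group and para to a large group, hydrogen can thus replace methoxy, with its 2 heavy atoms and 1 hydrogen-bond acceptor, and the number stays within the scatter for this pair. No evidence is at hand that bears on why this step is so small.

This single pair leaves open whether removing the methoxy group that remains in compound 4 would also stay within the scatter, and whether fluorine, a hydroxyl group or an ethoxy group on the same aromatic carbon would do so. It also leaves open what a single change elsewhere would do, such as an amide in place of the amine in the chain, or a longer chain with the 3-methoxybenzyl end of compound 4 kept.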